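Swapping the pyridin-2-yl group for a ring-free chain

The source may hold more compounds than are shown below. What is called first, only, known or untested is meant among the compounds shown, and "the series" means these compounds.

Compound 1 `CCOC(=O)C1=C(N/C=N/c2ccccn2)Nc2[nH]nc(C)c2C1c1ccc(N(C)C)cc1`: 29200 nM
Compound 2 `CCOC(=O)C1=C(N/C=N/c2ccc([N+](=O)[O-])cc2)Nc2[nH]nc(C)c2C1c1ccc(N(C)C)cc1`: 57800 nM
Compound 3 `CCOC(=O)C1=C(N/C=N/c2ccc(C)cc2)Nc2[nH]nc(C)c2C1c1ccc(N(C)C)cc1`: 43200 nM

These three compounds were tested in a functional assay on HeLa cells (Homo sapiens) for inhibition, read by MTT assay, with a stated time of 48 h; on this read-out higher numbers stand for weaker inhibition and lower numbers for stronger inhibition. Compound 1 gives the lowest of the three numbers, but its neighbours sit close: a 2.0-fold higher number from compound 1 to compound 2 (0.30 log units; within the scatter) and a 1.5-fold higher number from compound 1 to compound 3 (0.17 log units; within the scatter), while a 1.3-fold lower number from compound 2 to compound 3 (0.13 log units; within the scatter) is also small. All three values lie within the usual scatter of one another, so no ordering can be claimed.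

Compound 4 `CCOC(=O)C1=C(N/N=C(/C#N)C(=O)OCC)Nc2[nH]nc(C)c2C1c1ccc(N(C)C)cc1` has not yet been tested. It differs from compound 1 in one place: a group of 9 heavy atoms (5 carbon, 2 nitrogen, 2 oxygen; no ring) in place of a group of 8 heavy atoms (6 carbon, 2 nitrogen; one six-membered aromatic ring with 1 hetero atom), on an amine nitrogen. The measured steps only exchanged one ring for another on the double-bonded nitrogen, and each stayed within the scatter; none introduced a group with no ring, so they offer little guidance. The expectation is that compound 4 stays near compound 1, with a 1.2-fold higher number from compound 1 to compound 4 (0.08 log units; within the scatter) expected to be small. Compound 4 is therefore estimated at 35000 nM, with a range from 12000 nM to 100000 nM.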

Compound 4, half-maximal inhibitory concentration: 39200 nM
Compound 4: middle estimate off by 1.1-fold (0.05 log units), on the low side; the range from low to high includes it.
By their numbers in this assay, from the lowest: compounds 1, 4, 3 and 2 (each within the scatter of the next).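

Replacing the ring with a group that has no ring leaves the number close to those of all three ring-bearing compounds (a 1.3-fold higher number from compound 1 to compound 4 (0.13 log units; within the scatter); a 1.1-fold lower number from compound 3 to compound 4 (0.04 log units; within the scatter); a 1.5-fold lower number from compound 2 to compound 4 (0.17 log units; within the scatter)). So, among these four compounds, a ring on this amine nitrogen is not required for a value in this range. No other measurement here bears on this result. Going by these compounds, what remains open is whether a shorter chain, or a chain carrying an amine or a carboxylic acid, would shift the number beyond the scatter.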